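The compounds below may be only part of what the source reports. "The series", "measured", "known", "first", "only" and "open" are said of these compounds alone.

Working notes on the series. Two compounds carry numbers in a functional assay on HUVEC cells (Homo sapiens) for antiproliferative activity, read by MTT assay, with a stated time of 48 h (on this read-out higher numbers stand for weaker inhibition and lower numbers for stronger inhibition), so far. Compound 1 `Cc1cc(=O)oc2cc(Sc3cccc(Cl)n3)ccc12` gives 5890 nM in this assay. Compound 2 `O=C(COc1ccc2ccc(=O)oc2c1)OCCOc1no[n+]([O-])c1S(=O)(=O)c1ccccc1` returns only > 20000 nM in this assay, and this is a limit of the assay rather than a number. Compound 2 therefore stands at the limit of > 20000 nM in this assay, at which 1 of the 2 values shown sits, and where it lies beyond that limit cannot be read from the data. Among the compounds with values here, no pair of measured compounds in this set differs in only one place, so no measured step exists to lean on.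

The next compound, compound 3 `Cc1cc(=O)oc2cc(OCC(=O)OCCOc3no[n+]([O-])c3S(=O)(=O)c3ccccc3)ccc12`, differs from compound 2 by a single change: methyl in place of hydrogen on an aromatic carbon. A change of this size, with compound 2 already at a limit, gives little ground for expecting a move beyond the scatter in this assay; the methyl is also the group that compound 1 carries at the same kind of position, though the rest of compound 1 differs. The expected step from compound 2 to compound 3 is an at least 1.1-fold lower number from compound 2 to compound 3 (0.04 log units; that floor lies within the scatter), that is, none beyond the scatter. Compound 3 is estimated at 18000 nM in this assay, with a range from 6000 nM to 40000 nM, and a real chance that the assay again reports only a limit.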

Compound 3, half-maximal inhibitory concentration: > 20000 nM
Compound 3: only a limit was reported; the forecaster's own chance of this, stated with the estimate: 55%; middle value at least 1.1-fold (0.04 log units) from the limit.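

No step can be read between compound 2 and compound 3 because both are reported only as limits in this assay: the limit of > 20000 nM in this assay, at which 2 of the 3 values shown sit.

The compounds shown leave open how far beyond that limit either compound lies, and whether methyl in place of hydrogen on an aromatic carbon changes the read-out at all.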